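Opening the Ring: From Aminocyclohexyl to Branched Chain

A few compounds are considered here, and "the series" means these few. Any claim that something is new, unique, unknown or untested is made for them only; others in the source may bear on it.

Within the data shown here, compound 3 `N[C@H]1CC[C@H](C(=O)Nc2cc3cc[nH]c(=O)c3cc2Cl)CC1` gives 330 nM in an assay on isolated protein for inhibition of Rho-associated protein kinase 2 (Homo sapiens) (on this read-out lower numbers stand for stronger inhibition and higher numbers for weaker inhibition), which places it second highest of the three numbers so far. Compound 2 `CC(C)[C@H](N)C(=O)Nc1cc2cc[nH]c(=O)c2cc1Cl` gives 12 nM in this assay, and compound 1 `CC(C)(C)C[C@H](N)C(=O)Nc1cc2cc[nH]c(=O)c2cc1Cl` gives 845 nM. The step of a 28-fold higher number from compound 2 to compound 3 (1.44 log units; beyond the scatter) is large, whereas the step of a 2.6-fold lower number from compound 1 to compound 3 (0.41 log units; beyond the scatter) is modest, and the step of a 70-fold lower number from compound 1 to compound 2 (1.85 log units; beyond the scatter) is again large.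

Compound 4 `CC(C)(C)C[C@@H](N)C(=O)Nc1cc2cc[nH]c(=O)c2cc1Cl` is reached from compound 3 by 1-amino-3,3-dimethylbutyl in place of 4-aminocyclohexyl on a carbonyl carbon. Among the measured compounds shown here, the step that bears on it most directly is a 2.6-fold lower number from compound 1 to compound 3 (0.41 log units; beyond the scatter): compound 1 carries the same 1-amino-3,3-dimethylbutyl group, though with the other configuration at its single stereocentre, and no measured pair shows what that configuration changes. Running the modest step backwards points to a number for compound 4 somewhat higher than that of compound 3, while the large step of a 28-fold higher number from compound 2 to compound 3 (1.44 log units; beyond the scatter) came from a different chain and does not argue for a drop. Compound 4 is therefore expected to show a 4.5-fold higher number from compound 3 to compound 4 (0.66 log units; beyond the scatter) in this assay. Compound 4 is estimated at 1500 nM, with a range from 400 nM to 6000 nM.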

Compound 4, half-maximal inhibitory concentration: 110 nM
For compound 4 the middle estimate is 14-fold (1.13 log units) above the measured one; measured number below the stated range.
By their numbers in this assay, from the lowest: compound 2; then compound 4; then compound 3; then compound 1.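

The two compounds with the 1-amino-3,3-dimethylbutyl group show that the configuration at this saturated chain carbon matters on its own, with a 7.7-fold lower number from compound 1 to compound 4 (0.89 log units; beyond the scatter) in this assay, and this gap can be assigned to the stereocentre alone because nothing else changes: the fact that compounds 1 and 4 differ only in the configuration as drawn

The comparison with the ring also turns on that configuration: a 3.0-fold lower number from compound 3 to compound 4 (0.48 log units; beyond the scatter), so the R form of the open chain gives a lower number than 4-aminocyclohexyl on the carbonyl carbon, while compound 1, the S form, gives a higher one. Even so, the R form does not reach the branched chain of compound 2, with a 9.2-fold higher number from compound 2 to compound 4 (0.96 log units; beyond the scatter), and since compound 2 is drawn with the arrangement of compound 1, this step carries a change of configuration along with the change of chain and does not measure the chain alone.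

As far as these compounds go, what the R configuration does with the smaller 1-amino-2-methylpropyl group remains open, so it is not known whether the preference seen here holds for other chains. From the compounds shown here alone, how a simple methyl group on this chain carbon, or a methylated amine in place of the free amine, would behave also stays unknown.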